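Removing one methoxy group from a chalcone-pyrazole series

This account rests on a few compounds, and the source may have more. Where it says the series, first, only, none or still open, it means among the compounds named here.

Three compounds that share a pyrazole linked through a double bond to a ketone have been tested. Compound 1 `COc1ccc(-c2cc(/C=C/C(=O)c3ccc(N)cc3)[nH]n2)cc1` gives 2670 nM in a functional assay on M14 cells (Homo sapiens) for inhibition, read by sulforhodamine B assay, with a stated time of 48 h; on this read-out lower numbers stand for stronger inhibition of growth and higher numbers for weaker inhibition of growth. Compound 2 `COc1ccc(-c2cc(/C=C/C(=O)c3ccc(N)cc3)[nH]n2)cc1OC` gives 2280 nM in this assay, and compound 3 `COc1cc(C(=O)/C=C/c2cc(-c3cc(OC)c(OC)c(OC)c3)n[nH]2)cc(OC)c1OC` gives 1790 nM. The change from compound 2 to compound 1 is hydrogen in place of methoxy on an aromatic carbon, and it produced a 1.2-fold higher number from compound 2 to compound 1 (0.07 log units; within the scatter). Compound 4 `COc1ccc(-c2cc(/C=C/C(=O)c3cc(OC)c(OC)c(OC)c3)[nH]n2)cc1OC` arises from compound 3 by the same kind of change, (hydrogen in place of methoxy on an aromatic carbon); here the place is also meta to a methoxy group, which the earlier place was not. How the cores of compound 2 and compound 3 differ is not broken down here. Because the earlier step was a 1.2-fold higher number from compound 2 to compound 1 (0.07 log units; within the scatter), a similarly small step, a 1.2-fold higher number from compound 3 to compound 4 (0.07 log units; within the scatter), is expected for compound 4. Compound 4 is therefore estimated at 2100 nM in this assay, most likely between 1000 nM and 4500 nM.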

Compound 4, concentration for 50% growth inhibition: 1800 nM
Compound 4: the middle estimate sits 1.2-fold (0.07 log units) above what was measured; low and high end bracket the measured number.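

In this assay, putting hydrogen in place of methoxy gave a 1.0-fold higher number from compound 3 to compound 4 (0.00 log units; within the scatter), so this step is as small as the earlier one. Set side by side, the two steps agree: the same change on two cores in this assay, a 1.2-fold higher number (0.07 log units; within the scatter) from compound 2 to compound 1 and a 1.0-fold higher number (0.00 log units; within the scatter) from compound 3 to compound 4, 1.2-fold (0.07 log units) apart, within the scatter of two such steps. On these two cores the change can be carried across with a small step expected, but this does not show that it would stay small on a third core, and two steps that both lie within the scatter cannot reveal a slight difference between cores.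

The compounds shown leave open whether a hydroxyl group or a carboxylic acid at the same place would move the number beyond the scatter. They also leave open what a larger group, such as a longer alkoxy chain, would do there.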